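Shifting the methoxy group on the aryl ring of a triazole

The source may hold more compounds than are shown below. What is called first, only, known or untested is meant among the compounds shown, and "the series" means these compounds.

Measured compounds:
compound 1, `COc1cc(-n2ncnc2-c2cccc([N+](=O)[O-])c2)cc(OC)c1OC`: > 10000 nM
compound 2, `COc1ccc(-c2ncnn2-c2cc(OC)c(OC)c(OC)c2)cc1`: 120 nM
compound 3, `COc1cc(-n2ncnc2-c2ccc(SC)cc2)cc(OC)c1OC`: 500 nM

In a functional assay on HL-60 cells (Homo sapiens) for antiproliferative activity, read by MTT assay, with a stated time of 72 h (a lower number here means a stronger inhibitor, a higher number a weaker inhibitor), compound 1 gives > 10000 nM, which is a limit of the assay rather than a number (the limit of > 10000 nM in this assay, at which 1 of the 3 values shown sits). Among the two numbers, compound 3 stands highest: compound 2 reaches 120 nM, and the step of a 4.2-fold higher number from compound 2 to compound 3 (0.62 log units; beyond the scatter) separates them, lying beyond the scatter.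

Compound 4, `COc1cccc(-c2ncnn2-c2cc(OC)c(OC)c(OC)c2)c1`, has not yet been measured. It differs from compound 3 by 3-methoxyphenyl in place of 4-(methylsulfanyl)phenyl on an aromatic carbon. Within the data shown here, the one measured step, a 4.2-fold higher number from compound 2 to compound 3 (0.62 log units; beyond the scatter), exchanged a methoxy for a methylsulfanyl group and gave a modest weakening; it does not describe moving a methoxy group to a new position on the ring. Compound 1 carries a group at the same position as the incoming methoxy, and it sits at the limit. The writer therefore expects a weakening beyond the scatter, with wide uncertainty. Compound 4 is expected to give about 2000 nM, between 400 nM and 10000 nM. That estimate corresponds to an expected step of a 4.0-fold higher number from compound 3 to compound 4 (0.60 log units; beyond the scatter).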

Compound 4, half-maximal inhibitory concentration: > 10000 nM
Compound 4 gave a limit, no number; the forecaster's own chance of this, stated with the estimate: 20%; middle value at least 5.0-fold (0.69 log units) from the limit.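

Only the place of the methoxy group on the aryl ring differs between compound 2 and compound 4, and in this assay that move alone gives an at least 83-fold higher number from compound 2 to compound 4 (1.92 log units; beyond the scatter). Measured against the methylsulfanyl compound, the change gives an at least 20-fold higher number from compound 3 to compound 4 (1.30 log units; beyond the scatter), so the 4-substituted compounds give numbers here while the 3-methoxyphenyl compound does not. With methoxy in place of nitro, the step from compound 1 to compound 4 cannot be read, as both values are limits of the assay: the limit of > 10000 nM in this assay, at which 2 of the 4 values shown sit.

On these data alone, how far past its limit compound 4 lies remains open. Also open, as far as these compounds go, is whether any other group at that place on the ring, such as an amine, a hydroxyl or a fluorine atom, would return a measurable number.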